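This account rests on a few compounds, and the source may have more. Where it says the series, first, only, none or still open, it means among the compounds named here.

Of the compounds shown here, two with a shared core have already been measured. Compound 1 `c1ccc(OCCCCOc2cccc(-c3cc4cc(C5=NCCN5)ccc4o3)c2)cc1` gives 9500 nM in an ADME assay on L6 cells (Rattus norvegicus) for cytotoxicity, read by resazurin assay, with a stated time of 70 h; on this read-out lower numbers stand for stronger inhibition and higher numbers for weaker inhibition. Compound 2 `CC(C)NC(=N)c1ccc2oc(-c3cccc(OCCCCCCOc4ccccc4)c3)cc2c1` gives 7400 nM in this assay, which is the lowest of the two numbers; compound 1 is the nearest to it, and the gap between the two lies within the scatter, so neither can be called the stronger. Compound 3 `c1ccc(OCCCCCCOc2cccc(-c3cc4cc(C5=NCCN5)ccc4o3)c2)cc1` has not yet been measured. It differs from compound 2 in one place: a group of 5 heavy atoms (3 carbon, 2 nitrogen; one five-membered non-aromatic ring with 2 hetero atoms) in place of a group of 6 heavy atoms (4 carbon, 2 nitrogen; no ring), on an aromatic carbon. Compound 1 already carries this five-membered ring and sits within the scatter of compound 2, so no step beyond the scatter is expected in either direction for this assay. Compound 3 is therefore expected to give about 8500 nM in this assay, most likely between 4000 nM and 18000 nM. The expected step from compound 2 to compound 3 is a 1.1-fold higher number from compound 2 to compound 3 (0.06 log units; within the scatter).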

Compound 3, half-maximal inhibitory concentration: 2500 nM
Compound 3: middle estimate off by 3.4-fold (0.53 log units), on the high side; the whole stated range lies above it.
By their numbers in this assay, from the lowest: compound 3; then compounds 2 and 1 (each within the scatter of the next).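

In this assay, replacing the open-chain group on the aromatic carbon with the five-membered non-aromatic ring, while the rest of the molecule stays the same, gives a clear change (a 3.0-fold lower number from compound 2 to compound 3 (0.47 log units; beyond the scatter)), so this position affects the read-out when the chain ends in 2-phenoxyethyl. Keeping the ring and putting 2-phenoxyethyl in place of phenoxy on the saturated chain carbon also gives a clear change (a 3.8-fold lower number from compound 1 to compound 3 (0.58 log units; beyond the scatter)), so the far end of the chain matters too, and compound 3 is the one that carries both features. No measurement here explains why either change has this effect.

Going by these compounds, whether a still longer chain would lower the number further remains open. So does the effect of an amine or a carboxylic acid on the same aromatic carbon.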